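Propyl in place of vinyl on a nucleoside core

The compounds below may be only part of what the source reports. "The series", "measured", "known", "first", "only" and "open" are said of these compounds alone.

Going by the values given here, in a functional assay on L1210 cells (Mus musculus), read by MTT assay (a lower number here means a stronger inhibitor, a higher number a weaker inhibitor), compound 1 `C=C[C@@]1(O)[C@@H](CO)O[C@@H](n2ccc(=O)[nH]c2=O)[C@@H]1O` gives 148000 nM, the only actual number among the three values shown. Compound 2 `C#C[C@@H]1[C@@H](O)[C@H](n2ccc(=O)[nH]c2=O)O[C@@H]1CO` reaches only an assay limit of > 350000 nM in this assay. Compound 3 `C#CC[C@]1(O)[C@@H](CO)OC(n2ccc(N)nc2=O)[C@@H]1O` likewise stops at a limit of > 350000 nM, so that the picture is set by the limit of > 350000 nM in this assay, at which 2 of the 3 values shown sit. Compound 4 `CCC[C@@]1(O)[C@@H](CO)O[C@@H](n2ccc(=O)[nH]c2=O)[C@@H]1O` differs from compound 1 by propyl in place of vinyl on a saturated ring carbon. Among the compounds with values here, no measured pair here shares that change, so the size of the step is open; since compound 1 already sits close to the limit, a move beyond the scatter toward weaker inhibition seems the more likely outcome. Compound 4 is therefore expected at about 250000 nM, within 90000 nM to 600000 nM. This estimate for compound 4 means an expected step of a 1.7-fold higher number from compound 1 to compound 4 (0.23 log units; within the scatter).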

Compound 4, half-maximal inhibitory concentration: > 350000 nM
Compound 4: only a limit was reported; the forecaster's own chance of this, stated with the estimate: 40%; at least 1.4-fold (0.14 log units) between middle value and limit.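

In this assay, going by these compounds alone, propyl in place of vinyl on this saturated ring carbon gives an at least 2.3-fold higher number from compound 1 to compound 4 (0.37 log units; beyond the scatter), the first step that can be read at this position. For compound 4, the reading of > 350000 nM is a limit, so the step has a lower bound but no measured size. Compound 1 remains the only compound with an actual number: the limit of > 350000 nM in this assay, at which 3 of the 4 values shown sit.

This single step does not separate the loss of the double bond from the longer chain. On these data alone, how ethyl at this position would read stays open.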